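One Amide Substituent Swap and Cell Tolerance

The compounds below may be only part of what the source reports. "The series", "measured", "known", "first", "only" and "open" are said of these compounds alone.

Compound 1 `COc1ccc2c(=O)c(/C=C/C(=O)Nc3ccc(Cl)cc3)coc2c1` is one of two compounds tested in an ADME assay on HepG2 2.2.15 cells (Homo sapiens) for cytotoxicity, read by MTT assay, with stated times of 48 h and 9 days; a lower number here means that less compound is tolerated, a higher number that more compound is tolerated; compound 1 gives 272000 nM, the highest of the two numbers. Compound 2 `COc1ccc2c(=O)c(/C=C/C(=O)NCc3ccc(C)cc3)coc2c1` gives 257000 nM, and the step of a 1.1-fold lower number from compound 1 to compound 2 (0.02 log units; within the scatter) shows how little that swap mattered. Compound 3 `COc1ccc2c(=O)c(/C=C/C(=O)NCc3ccc(F)cc3F)coc2c1` is not yet measured; it differs from compound 1 by 2,4-difluorobenzyl in place of 4-chlorophenyl on an amide-type nitrogen. For the measured compounds named here, the only measured step bearing on this, a 1.1-fold lower number from compound 1 to compound 2 (0.02 log units; within the scatter), also puts a 4-methylbenzyl in place of the 4-chlorophenyl on the same nitrogen, so no step beyond the scatter is expected, a 1.0-fold lower number from compound 1 to compound 3 (0.02 log units; within the scatter). Compound 3 is estimated at 260000 nM, ranging from 130000 nM to 520000 nM.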

Compound 3, half-maximal cytotoxic concentration: 79300 nM
For compound 3 the middle estimate is 3.3-fold (0.52 log units) above the measured one; the whole stated range lies above it.
By their numbers in this assay, from the lowest: compound 3; then compounds 2 and 1 (each within the scatter of the next).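

In this assay, the group on the amide nitrogen turns out to matter more than the first pair suggested: a 3.4-fold lower number from compound 1 to compound 3 (0.54 log units; beyond the scatter), and a 3.2-fold lower number from compound 2 to compound 3 (0.51 log units; beyond the scatter). The second step keeps the saturated chain carbon and changes only the ring attached to it, so 2,4-difluorophenyl in place of 4-methylphenyl is enough to lower the number beyond the scatter. No measurement shown offers a reason for this drop.

As far as these compounds go, whether a benzyl group carrying a single fluorine would sit nearer compound 2 or compound 3 remains open, as does the outcome with an amine or a carboxylic acid on that ring.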